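The source may report more compounds than this note shows. Statements on the series, on what has been measured and on what is new or still open speak of the compounds shown alone.

Compound 1, `CSc1ncnc2c1c(-c1ccccc1)cn2[C@@H]1O[C@H](CO)[C@@H](O)[C@H]1O`: in a functional assay on CEM-DNR-bulk cells (Homo sapiens), read by MTT assay, with a stated time of 72 h (a lower number here means a stronger inhibitor, a higher number a weaker inhibitor), compound 1 gives > 20000 nM, which is a limit of the assay rather than a number.
Compound 2, `C#Cc1cn([C@@H]2O[C@H](CO)[C@@H](O)[C@H]2O)c2ncnc(NC)c12`: in this assay compound 2 gives 18500 nM.
Compound 3, `CNc1ncnc2c1c(-c1ccsc1)cn2[C@@H]1O[C@H](CO)[C@@H](O)[C@H]1O`: in this assay compound 3 gives > 20000 nM, again a limit of the assay.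

Compound 3 therefore stands at the edge of what this assay can report. For the measured compounds named here, the only step that reaches it, an at least 1.0-fold higher number from compound 2 to compound 3 (0.03 log units; that floor lies within the scatter), shows merely that the change did not bring a lower number. Of the values shown, (the limit of > 20000 nM in this assay, at which 2 of the 3 values shown sit), so there is little to compare.

Compound 4, `CSc1ncnc2c1c(-c1ccsc1)cn2[C@@H]1O[C@H](CO)[C@@H](O)[C@H]1O`, differs from compound 3 by methylsulfanyl in place of methylamino on an aromatic carbon. Going by the values given here, no measured step swaps these two groups on their own; compound 1 carries methylsulfanyl and compound 3 carries methylamino, but the two also differ in another place, and both sit at the limit. With nothing pointing to a change beyond the scatter, the step that the limit leaves unreadable from compound 3 to compound 4 is expected to be flat. Compound 4 is thus estimated at 25000 nM, within 8000 nM to 80000 nM, most likely reported only as a limit.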

Compound 4, half-maximal inhibitory concentration: > 20000 nM
Compound 4: no number, only a limit (the forecaster's own chance of this, stated with the estimate: 80%); the middle value lies beyond the limit too.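

The steps from compound 3 to compound 4 and from compound 1 to compound 4 cannot be read: all three compounds give only a limit in this assay. Left open is whether methylsulfanyl in place of methylamino, or thiophen-3-yl in place of phenyl, changes the activity at all.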